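Iodo to nitro at a different place on the ring

This account rests on a few compounds, and the source may have more. Where it says the series, first, only, none or still open, it means among the compounds named here.

Of the compounds shown here, three have so far been measured in a functional assay on MCF7 cells (Homo sapiens) for cytotoxicity, read by MTT assay, with a stated time of 48 h; a higher number here means a weaker inhibitor, a lower number a stronger inhibitor. Compound 1 `CC(=NNC(=S)Nc1cccc([N+](=O)[O-])c1)c1ccccn1` gives 38 nM, and compound 2 `CC(=NNC(=S)Nc1cccc(I)c1)c1ccccn1` gives 45 nM. Compound 3 `C/C(=N/NC(=S)Nc1ccccc1I)c1ccccn1` has the same atoms as compound 2, joined differently; the difference between the two cores is not broken down here. In this assay compound 3 gives 4.1 nM. Compound 4 `C/C(=N/NC(=S)Nc1ccccc1[N+](=O)[O-])c1ccccn1` has not yet been measured. It differs from compound 3 by nitro in place of iodo on an aromatic carbon. The same kind of change separates compound 2 from compound 1, (nitro in place of iodo on an aromatic carbon), but there the place is meta to a large group, whereas in compound 4 it is ortho to a large group. That earlier change gave a 1.2-fold lower number from compound 2 to compound 1 (0.07 log units; within the scatter). Resting on the step of a 1.2-fold lower number from compound 2 to compound 1 (0.07 log units; within the scatter), a similarly small step is expected from compound 3 to compound 4, a 1.5-fold higher number from compound 3 to compound 4 (0.17 log units; within the scatter), with the different place adding some uncertainty. Compound 4 is therefore estimated at 6 nM, with a likely range from 2 nM to 20 nM.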

Compound 4, half-maximal inhibitory concentration: 5.7 nM
The estimate for compound 4 lay 1.1-fold (0.02 log units) above the measured number; the measured number falls inside the stated range.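

In this assay, putting nitro in place of iodo gives a 1.4-fold higher number from compound 3 to compound 4 (0.14 log units; within the scatter), so compound 3 and compound 4 cannot be told apart. The same exchange on the other core gave a matching result, and the two steps agree: the same change on two cores in this assay, a 1.2-fold lower number (0.07 log units; within the scatter) from compound 2 to compound 1 and a 1.4-fold higher number (0.14 log units; within the scatter) from compound 3 to compound 4, 1.6-fold (0.22 log units) apart, within the scatter of two such steps. This shows that the exchange carried over between these two cores in this one assay, but two pairs cannot show that it will hold on other cores, and they do not explain why the two groups give such similar numbers.

From the compounds shown here alone, it remains open whether other groups ortho to a large group, such as an amine or a carboxylic acid, would also match iodo and nitro. The same question applies to these groups on the core of compound 1.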